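The compounds below may be only part of what the source reports. "The series", "measured", "known", "first", "only" and "open" are said of these compounds alone.

Measured in a functional assay on HCC827 cells (Homo sapiens) for antiproliferative activity, read by MTT assay, with a stated time of 72 h; a higher number here means a weaker inhibitor, a lower number a stronger inhibitor:

- compound 1 `CN1CCN(c2ccc(Nc3ncc4nc([S+]([O-])c5ccccc5)n([C@H]5CC[C@H](O)CC5)c4n3)cc2)CC1`: 268 nM
- compound 2 `CN1CCN(c2ccc(Nc3ncc4nc([S+]([O-])c5ccccc5)n(C5CCCC5)c4n3)cc2)CC1`: 64.7 nM
- compound 3 `CC(C)n1c([S+]([O-])c2ccccc2)nc2cnc(Nc3ccc(N4CCN(C)CC4)cc3)nc21`: 215 nM

Compound 3 gives 215 nM. That puts it level with one neighbour, a 1.2-fold lower number from compound 1 to compound 3 (0.10 log units; within the scatter), and clearly apart from the other, a 3.3-fold higher number from compound 2 to compound 3 (0.52 log units; beyond the scatter).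

The next compound, compound 4 `CN1CCN(c2ccc(Nc3ncc4nc([S+]([O-])c5ccccc5)n(C5CC5)c4n3)cc2)CC1`, has cyclopropyl in place of isopropyl on an aromatic nitrogen. For the measured compounds named here, only changes at this same nitrogen can guide an expectation, and no measured compound carries cyclopropyl. The third such step is a 4.1-fold lower number from compound 1 to compound 2 (0.62 log units; beyond the scatter), so these steps range from nothing beyond the scatter to modest. A ring at this nitrogen does not settle the number: compound 1 with 4-hydroxycyclohexyl and compound 2 with cyclopentyl both carry one, yet their values sit apart. With so little to go on, no step beyond the scatter is expected in this assay, and the estimated step is a 1.1-fold lower number from compound 3 to compound 4 (0.03 log units; within the scatter). Compound 4 is estimated at 200 nM, with an expected range from 80 nM to 500 nM.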

Compound 4, half-maximal inhibitory concentration: 1630 nM
Compound 4: middle estimate off by 8.2-fold (0.91 log units), on the low side, outside the stated range (above it).
By their numbers in this assay, from the lowest: compound 2; then compounds 3 and 1 (each within the scatter of the next); then compound 4.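

In this assay, replacing isopropyl with cyclopropyl leaves the count of heavy atoms unchanged yet gives a 7.6-fold higher number from compound 3 to compound 4 (0.88 log units; beyond the scatter), so tying the same carbons into a small ring matters at this nitrogen even though the group barely grows. Having a ring there is also no advantage in itself: cyclopropyl compares poorly with cyclopentyl, with a 25-fold higher number from compound 2 to compound 4 (1.40 log units; beyond the scatter), and with 4-hydroxycyclohexyl, with a 6.1-fold higher number from compound 1 to compound 4 (0.78 log units; beyond the scatter), which makes compound 4 the weakest inhibitor of the four. No measured evidence is available to explain this loss of activity.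

Cyclobutyl and unsubstituted cyclohexyl remain open, so it is unclear how activity changes as the ring grows from cyclopropyl to cyclopentyl and beyond. As far as these compounds go, whether a straight propyl chain or a tert-butyl group at this nitrogen would behave more like isopropyl or like cyclopropyl also remains unknown.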